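Replacing 1-methylbutyl with 5-(dipropylamino)pentyl at the assay limit

This account rests on a few compounds, and the source may have more. Where it says the series, first, only, none or still open, it means among the compounds named here.

Measured in a functional assay on DU-145 cells (Homo sapiens) for antiproliferative activity, read by WST assay, with a stated time of 3 days; on this read-out lower numbers stand for stronger inhibition and higher numbers for weaker inhibition:
- Compound 1 `CCCCCCCOc1c(-c2cc(OC)c(OC)c(OC)c2)oc2ccccc2c1=O`: > 50000 nM (a limit)
- Compound 2 `COc1cc(-c2oc3ccccc3c(=O)c2OC(C)C)cc(OC)c1OC`: > 50000 nM (a limit)
- Compound 3 `CCCC(C)Oc1c(-c2cc(OC)c(OC)c(OC)c2)oc2ccccc2c1=O`: > 50000 nM (a limit)

Compound 3 has no exact number, only the limit > 50000 nM. The same holds for the whole set, with the limit of > 50000 nM in this assay, at which 3 of the 3 values shown sit.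

Compound 4 `CCCN(CCC)CCCCCOc1c(-c2cc(OC)c(OC)c(OC)c2)oc2ccccc2c1=O` keeps the shared core but carries 5-(dipropylamino)pentyl in place of 1-methylbutyl on an oxygen on an aromatic ring.

Within the data shown here, three measured steps bear on this change, all of them swaps among plain alkyl chains at that same oxygen. They are a step that the two limits leave unreadable from compound 1 to compound 2, a step that the two limits leave unreadable from compound 1 to compound 3 and a step that the two limits leave unreadable from compound 2 to compound 3. None has a readable size, so they show only that heptyl, isopropyl and 1-methylbutyl all leave the compounds at the limit in this assay.

The entering chain is of a different kind from these three, so those steps say little about it. A move towards stronger inhibition is a cautious expectation, and compound 4 may yet stay at the limit. The expected size of the change is an at least 5.0-fold lower number from compound 3 to compound 4 (0.69 log units; beyond the scatter). For compound 4 the estimated value is 10000 nM, with an expected range from 2500 nM to 50000 nM.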

Compound 4, half-maximal inhibitory concentration: 24200 nM
The estimate for compound 4 lay 2.4-fold (0.38 log units) below the measured number; low and high end bracket the measured number.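

In this assay, the oxygen on the aromatic ring turns out to be a place where the choice of chain can bring a compound off the limit, as 5-(dipropylamino)pentyl gives an at least 2.0-fold lower number from compound 3 to compound 4 (0.31 log units; beyond the scatter), an at least 2.0-fold lower number from compound 2 to compound 4 (0.31 log units; beyond the scatter) and an at least 2.0-fold lower number from compound 1 to compound 4 (0.31 log units; beyond the scatter). The last of these steps is the most telling, since it amounts to dipropylamino in place of ethyl on a saturated chain carbon, five bonds along the chain from that oxygen, and so among the compounds shown, only the chain carrying an amine gives a readable number. All three steps give only the smallest possible size, because the compounds on their starting side sit at a limit: the limit of > 50000 nM in this assay, at which 3 of the 4 values shown sit.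

The compounds shown leave open how large these steps really are, and whether the change belongs to the dipropylamino group itself or to how far along the chain it sits. A shorter chain carrying the same amine, or a pentyl chain carrying dimethylamino, morpholine or a carboxylic acid instead, would bear on both questions.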